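This account rests on a few compounds, and the source may have more. Where it says the series, first, only, none or still open, it means among the compounds named here.

Compound 1: `COc1ccc(C(=O)c2cc(C)ccc2OCC(=O)NNC(=O)c2cc3ccccc3oc2=O)cc1` gives 43500 nM in a functional assay on DLA cells (Mus musculus) for cytotoxicity, read by trypan blue exclusion, with a stated time of 48 h; a higher number here means a weaker inhibitor, a lower number a stronger inhibitor.
Compound 2: `Cc1ccc(OCC(=O)NNC(=O)c2cc3ccccc3oc2=O)c(C(=O)c2ccccc2Br)c1` gives 10000 nM in this assay.
Compound 3: `Cc1ccc(OCC(=O)NNC(=O)c2cc3ccccc3oc2=O)c(C(=O)c2ccc(Cl)cc2)c1` gives 61600 nM in this assay.

Among these three, compound 3 has the highest number. The gap to compound 1 is small: a 1.4-fold higher number from compound 1 to compound 3 (0.15 log units; within the scatter). The gap to compound 2 is larger: a 6.2-fold higher number from compound 2 to compound 3 (0.79 log units; beyond the scatter). So compound 3 and compound 1 sit close together, while compound 2 stands apart with a lower number.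

Compound 4, `Cc1ccc(OCC(=O)NNC(=O)c2cc3ccccc3oc2=O)c(C(=O)c2ccc(Br)cc2)c1`, differs from compound 3 in one place: bromo in place of chloro on an aromatic carbon. This swaps one halogen for another on the same aromatic carbon, para to a large group.

For the measured compounds named here, no measured step repeats this exact swap. The closest comparison is the change from methoxy to chloro at that carbon, a 1.4-fold higher number from compound 1 to compound 3 (0.15 log units; within the scatter), which stayed within the scatter. The larger step, a 6.2-fold higher number from compound 2 to compound 3 (0.79 log units; beyond the scatter), involved a different ring position and does not speak to this swap. The step from compound 3 to compound 4 is therefore expected to be small, with no direction beyond the scatter: a 1.2-fold lower number from compound 3 to compound 4 (0.09 log units; within the scatter). Compound 4 is estimated at 50000 nM, within 25000 nM to 120000 nM.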

Compound 4, half-maximal inhibitory concentration: 95500 nM
The estimate for compound 4 lay 1.9-fold (0.28 log units) below the measured number, within the range that was stated.
By their numbers in this assay, from the lowest: compound 2; then compounds 1, 3 and 4 (each within the scatter of the next, the first and the last beyond it).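

Bromo in place of chloro on this aromatic carbon makes no clear difference (a 1.6-fold higher number from compound 3 to compound 4 (0.19 log units; within the scatter)), so these two halogens cannot be told apart at this position. Keeping the bromine and changing only where it sits on the ring, from 2-bromophenyl to 4-bromophenyl, gives a clear shift towards weaker inhibition (a 9.6-fold higher number from compound 2 to compound 4 (0.98 log units; beyond the scatter)), a comparison in which the halogen itself stays the same. Bromo in place of methoxy lands just beyond the scatter (a 2.2-fold higher number from compound 1 to compound 4 (0.34 log units; beyond the scatter)), whereas chloro in place of methoxy stayed within it, so the two halogens are not separated from methoxy equally.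

No measurement at hand explains these differences. Open too, from the compounds shown here alone, is how an amine or a carboxylic acid on this same aromatic carbon would behave, and whether 2-chlorophenyl would match 2-bromophenyl.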